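The source may hold more compounds than are shown below. What is called first, only, known or untested is meant among the compounds shown, and "the series" means these compounds.

Measured so far in an ADME assay on microsomes from liver (Homo sapiens) for metabolic stability, read by LC-MS, with a stated time of 30 min, tested at 1 uM; on this read-out lower numbers stand for slow clearance and higher numbers for fast clearance:
Compound 1 `C[C@@H](c1ccc2ncccc2c1)c1nnc2ccc(-c3cccc(C#N)c3)nn12`: 17.9 mL.min-1.g-1
Compound 2 `Nc1ccc2nnc(Cc3ccc4ncccc4c3)n2n1`: < 7.6 mL.min-1.g-1 (a limit of the assay, not a number)
Compound 3 `CCS(=O)(=O)c1ccc(-c2ccc3nnc([C@@H](C)c4ccc5ncccc5c4)n3n2)cc1`: 10.4 mL.min-1.g-1

Among the measured compounds shown here, only two of the three compounds have a true number in this assay. Compound 1 stands at 17.9 mL.min-1.g-1, and compound 3, at 10.4 mL.min-1.g-1, lies within the scatter of it. Compound 2 is reported only as a limit, < 7.6 mL.min-1.g-1.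

The account now follows the step from compound 1 to compound 4 `C[C@@H](c1ccc2ncccc2c1)c1nnc2ccc(-c3ccc(N(C)C)nc3)nn12`. Compound 4 has 6-(dimethylamino)pyridin-3-yl in place of 3-cyanophenyl on an aromatic carbon of the core of compound 1 (6-(dimethylamino)pyridin-3-yl in place of 3-cyanophenyl on an aromatic carbon).

For the measured compounds named here, no two measured compounds here differ in one place only, so the data give no direct measure of what such a change does in this assay. The expectation therefore starts from compound 1 at 17.9 mL.min-1.g-1. Only a small upward move is expected, and no change beyond the scatter is foreseen, as the estimated step of a 1.2-fold higher number from compound 1 to compound 4 (0.09 log units; within the scatter) shows. For compound 4 the expected value is 22 mL.min-1.g-1, with an estimated range from 11 mL.min-1.g-1 to 45 mL.min-1.g-1.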

Compound 4, intrinsic clearance in microsomes: 232 mL.min-1.g-1
The estimate for compound 4 lay 11-fold (1.02 log units) below the measured number; the measured number lies above the stated range.
By their numbers in this assay, from the lowest: compounds 3 and 1 (each within the scatter of the next); then compound 4. At a limit, below all of these: compound 2.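

In this assay, among the compounds shown here, setting 6-(dimethylamino)pyridin-3-yl in place of 3-cyanophenyl on the aromatic carbon of the shared core gives a 13-fold higher number from compound 1 to compound 4 (1.11 log units; beyond the scatter) as the first step that can be read. The earlier compounds shown here could not show this, since no two of them differed in one place only; now it is clear that the group carried on this carbon can, by itself, move intrinsic clearance well beyond the scatter. Nothing in the available evidence bears on why the number rises so steeply.

The step also changes two things at once, a carbon-only ring for one with a ring nitrogen, and a nitrile for a dimethylamino group, so the compounds shown do not tell which of these carries the rise. From the compounds shown here alone, it remains open whether a plain pyridin-3-yl, or a phenyl ring with the dimethylamino group, would follow compound 4 or stay close to compound 1, and whether a cyclic amine such as morpholine on the same ring would behave like dimethylamino.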